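Ester Against Acid at the Chain End of Compound 2

The source may report more compounds than this note shows. Statements on the series, on what has been measured and on what is new or still open speak of the compounds shown alone.

Compound 1, `C/C(=C\c1ccc2ccc(Cl)cc2n1)c1cccc(OC(C)C(=O)O)c1`: 1780 nM
Compound 2, `CCOC(=O)CCCOc1cccc(/C=C/c2ccc3ccccc3n2)c1`: 580 nM
Compound 3, `CC(Oc1cccc(C#Cc2ccc3ccc(Br)cc3n2)c1)C(=O)O`: 97 nM

Of the compounds shown here, three have been tested in a functional assay on lung (Cavia porcellus) for binding affinity to cysteinyl leukotriene receptor (Homo sapiens); a higher number here means a weaker inhibitor, a lower number a stronger inhibitor. Compound 2 gives 580 nM, the second highest of the three numbers. Compound 1 gives the higher number, 1780 nM, a gap beyond the scatter, and compound 3 gives the lowest number, 97 nM, again beyond the scatter. For the measured compounds named here, compound 1 and compound 3 both carry a carboxy group at the end of their side chain, whereas compound 2 is the only ester; no pair of measured compounds differs in just one place, so no single step can be read off directly.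

The next compound, compound 4, `O=C(O)CCCOc1cccc(/C=C/c2ccc3ccccc3n2)c1`, is compound 2 with one change: hydrogen in place of ethyl on an oxygen next to a carbonyl group

Going by the values given here, the measured set gives no direct precedent for this change. Since the two carboxy compounds bracket compound 2 on both sides, the expectation rests on the general behaviour of such ester-to-acid steps, and a moderate move toward a lower number is expected, with wide uncertainty. The step from compound 2 to compound 4 is estimated as a 2.3-fold lower number from compound 2 to compound 4 (0.37 log units; beyond the scatter). Compound 4 is therefore expected to give about 250 nM, with a likely range from 60 nM to 1000 nM.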

Compound 4, half-maximal inhibitory concentration: 480 nM
The estimate for compound 4 lay 1.9-fold (0.28 log units) below the measured number, and the stated range covers the measured number.
By their numbers in this assay, from the lowest: compound 3; then compounds 4 and 2 (each within the scatter of the next); then compound 1.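

In this assay, putting hydrogen in place of ethyl on an oxygen next to a carbonyl group gives a 1.2-fold lower number from compound 2 to compound 4 (0.08 log units; within the scatter) and so leaves the ethoxycarbonyl and carboxy forms of this chain end indistinguishable. The earlier compounds shown here differed in several places at once and could not isolate the chain end, whereas this pair does, showing that on this core and with this chain the carboxy group brings no change that can be read beyond the scatter, even though compound 1 and compound 3 also carry one. No measurement at hand bears on why the exchange has so little effect on the number.

Going by these compounds, whether the exchange would behave the same way on a shorter or longer chain, or on a core carrying chlorine or bromine, remains open. Also open, on these data alone, is how other groups at the chain end, such as a tetrazole, an amide or a sulfonamide, would compare with the ethoxycarbonyl and carboxy forms on this same core.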